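Adding a Methyl to the Weakest Coumarin-Pyrazole Ester

A few compounds are considered here, and "the series" means these few. Any claim that something is new, unique, unknown or untested is made for them only; others in the source may bear on it.

Compound 1 `CCOC(=O)c1c(-c2c(Cl)c3ccccc3oc2=O)nn(-c2cccc(C)c2)c1C(=O)OCC`: 30000 nM
Compound 2 `CCOC(=O)c1c(-c2c(Cl)c3cc(C)ccc3oc2=O)nn(-c2ccccc2)c1C(=O)OCC`: 228000 nM

Both measured compounds share the same core and were tested in a functional assay on HeLa cells (Homo sapiens) for cytotoxicity, read by MTT assay, with a stated time of 48 h; on this read-out higher numbers stand for weaker inhibition and lower numbers for stronger inhibition. Compound 1 gives 30000 nM, while compound 2 gives 228000 nM, the higher of the two numbers and thus the weaker inhibitor; the gap between them lies beyond the scatter of repeated measurements. The two compounds differ in two places at once, so no single change can be held responsible for that gap.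

Compound 3 `CCOC(=O)c1c(-c2c(Cl)c3cc(C)ccc3oc2=O)nn(-c2cccc(C)c2)c1C(=O)OCC` has not been measured. It differs from compound 2 in one place: methyl in place of hydrogen on an aromatic carbon of the phenyl group attached to the core. Among the measured compounds shown here, no measured pair isolates this change, so its effect is unknown. Given that compound 1, which also carries this methylphenyl group, shows 30000 nM, a small step toward a lower number is expected from compound 2 to compound 3, roughly a 1.9-fold lower number from compound 2 to compound 3 (0.28 log units; within the scatter), not far beyond the scatter. Compound 3 is therefore estimated at 120000 nM, with a range from 30000 nM to 450000 nM.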

Compound 3, half-maximal inhibitory concentration: 115000 nM
Compound 3: the middle estimate sits 1.0-fold (0.02 log units) above what was measured; the measured number falls inside the stated range.
By their numbers in this assay, from the lowest: compound 1; then compounds 3 and 2 (each within the scatter of the next).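

In this assay the change from phenyl to 3-methylphenyl gives a 2.0-fold lower number from compound 2 to compound 3 (0.30 log units; within the scatter) and so cannot be told apart from no effect at this position on the phenyl group. The same exchange of hydrogen for methyl at a different aromatic carbon, this time on the shared core, gives a 3.8-fold higher number from compound 1 to compound 3 (0.58 log units; beyond the scatter) and, of the two steps, only this one lies beyond the scatter. The two compounds first compared differed in two places at once, whereas these single-change steps show that the same small group need not give the same result at every aromatic carbon, although nothing shown gives a reason for either step.

Still open, as far as these compounds go, is whether a different group on that phenyl carbon, such as an amine, a carboxylic acid or a longer chain, would produce a step beyond the scatter. From the compounds shown here alone, each step also rests on a single pair of compounds, so it remains unknown whether either would hold if other parts of the molecule, such as the two ethyl esters, were replaced.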